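Compound 3: 4-methoxyphenyl in Place of Allyl on Compound 2

A few compounds are considered here, and "the series" means these few. Any claim that something is new, unique, unknown or untested is made for them only; others in the source may bear on it.

Two compounds share a core and carry different substituents. Compound 1 `C=CCNc1nnc(-c2cc(-c3ccc(F)cc3F)ccc2O)o1` and compound 2 `C=CCNc1nnc(-c2cc(-c3ccc(F)cc3F)ccc2O)s1` were tested in a functional assay on the whole organism (strain BALB/c) for inhibition, with Mus musculus as the target, read by paw edema, with a stated time of 4 h, at a dose of 50 mg/kg by the oral route; on this read-out higher numbers stand for more inhibition at the one dose given (going by the name of the read-out) and lower numbers for less inhibition. Compound 1 gives 36.6%, and compound 2 gives 57.2%. Compound 2 therefore stands highest of the two numbers shown, and compound 1 sits lower by a gap that lies beyond the usual scatter. No single-step comparison between them is available, so only these two values speak.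

Compound 3 `COc1ccc(Nc2nnc(-c3cc(-c4ccc(F)cc4F)ccc3O)s2)cc1` has not yet been measured in this assay. It differs from compound 2 as follows: 4-methoxyphenyl in place of allyl on a nitrogen on an aromatic ring. Going by the values given here, no measured pair shows how such a replacement plays out here, so the direction of the step is open. Compound 3 is expected to land near compound 2, with a step of a number 7.2 percentage points lower from compound 2 to compound 3 (within the scatter) that may well fall within the scatter. The estimated value for compound 3 is 50%, within a range from 30% to 70%.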

Compound 3, a percentage reported as inhibition, in the whole organism at one dose (the size of the read-out at that dose, not a potency): 55.3%
Compound 3: middle estimate off by 5.3 percentage points, on the low side; the range from low to high includes it.
By their numbers in this assay, from the lowest: compound 1; then compounds 3 and 2 (each within the scatter of the next).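

In this assay, going by these compounds alone, the change from allyl to 4-methoxyphenyl on a nitrogen on an aromatic ring gives a number 1.9 percentage points lower from compound 2 to compound 3 (within the scatter) and this is the first single-step comparison available. It shows that at this position the allyl chain and its double bond are not required for the read-out to remain at the level of compound 2, even with a six-membered aromatic ring and 8 heavy atoms in their place. Nothing measured explains why the two groups read alike.

Going by these compounds, whether a plain phenyl without the methoxy, a saturated propyl chain or a benzyl group on the same nitrogen would read alike remains open. A single dose and time point also leave open whether the two compounds would still match at other doses.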